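Varying the amide substituent on the shared core

The compounds below may be only part of what the source reports. "The series", "measured", "known", "first", "only" and "open" are said of these compounds alone.

Measured so far:
compound 1 `Cc1nc(S(C)(=O)=O)ccc1Oc1ncnc(OC2CCN(C(=O)C(F)(F)F)CC2)c1F` — 151 nM
compound 2 `CCC(F)(F)C(=O)N1CCC(Oc2ncnc(Oc3ccc(S(C)(=O)=O)nc3C)c2F)CC1` — 17.4 nM

In a functional assay on isolated protein for inhibition of Glucose-dependent insulinotropic receptor (Homo sapiens), read by HTRF and cAMP accumulation (a lower number here means that less compound is needed, a higher number that more compound is needed for the effect), compound 2 gives 17.4 nM, the lowest of the two numbers measured; its nearest neighbour is compound 1 with 151 nM, and the step of an 8.7-fold lower number from compound 1 to compound 2 (0.94 log units; beyond the scatter) separates them. Compound 3 `CCc1cnc(C(=O)N2CCC(Oc3ncnc(Oc4ccc(S(C)(=O)=O)nc4C)c3F)CC2)nc1` is not yet measured. It differs from compound 2 by 5-ethylpyrimidin-2-yl in place of 1,1-difluoropropyl on a carbonyl carbon. Among the measured compounds shown here, only one measured step bears on this position, an 8.7-fold lower number from compound 1 to compound 2 (0.94 log units; beyond the scatter), and it shows that the group on this carbonyl carbon can move the number beyond the scatter. For the measured compounds named here, no measured pair involves an aromatic ring entering at this carbonyl carbon, so the direction of the present change cannot be read from the data. The step of a 1.7-fold higher number from compound 2 to compound 3 (0.24 log units; within the scatter) is therefore expected to be small, with a wide range on either side. Compound 3 is expected to give 30 nM, estimated to lie between 6 nM and 200 nM.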

Compound 3, half-maximal effective concentration: 4.7 nM
Compound 3: the middle estimate sits 6.4-fold (0.81 log units) above what was measured; measured number below the stated range.
By their numbers in this assay, from the lowest: compound 3; then compound 2; then compound 1.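

In this assay, the group on this carbonyl carbon need not be a fluorinated chain: 5-ethylpyrimidin-2-yl, the first aromatic ring at this place, gives a lower number than either 1,1-difluoropropyl (a 3.7-fold lower number from compound 2 to compound 3 (0.57 log units; beyond the scatter)) or trifluoromethyl (a 32-fold lower number from compound 1 to compound 3 (1.51 log units; beyond the scatter)). Both steps lie beyond the scatter, so compound 3 now stands lowest of the three amides on the shared core. Nothing on hand accounts for the effect of this ring on the number.

The ring, its two nitrogen atoms and the ethyl group enter together, so their separate shares in the step remain unresolved. A phenyl ring, an unsubstituted pyrimidin-2-yl or a 5-methoxypyrimidin-2-yl on the same carbonyl carbon would help to separate them.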